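From 3,4-dimethoxyphenyl to phenyl: predicting compound 4

The source may report more compounds than this note shows. Statements on the series, on what has been measured and on what is new or still open speak of the compounds shown alone.

Measured in a functional assay on COLO 205 cells (Homo sapiens) for inhibition, read by sulforhodamine B assay, with a stated time of 48 h, tested at 50 uM; on this read-out higher numbers stand for more inhibition of growth at the one concentration tested and lower numbers for less inhibition of growth
- Compound 1 `COc1cc(/C=C/C(=O)/C=C/c2cccc3ccccc23)ccc1OCc1cn(CCOc2cc(=O)oc3ccccc23)nn1` gives 85%
- Compound 2 `COc1cc(/C=C/C(=O)/C=C/c2cccs2)ccc1OCc1cn(CCOc2cc(=O)oc3ccccc23)nn1` gives 66%
- Compound 3 `COc1ccc(/C=C/C(=O)/C=C/c2ccc(OCc3cn(CCOc4cc(=O)oc5ccccc45)nn3)c(OC)c2)cc1OC` gives 80%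

Compound 3 lies within the scatter of compound 1 and beyond the scatter from compound 2. Compound 4 `COc1cc(/C=C/C(=O)/C=C/c2ccccc2)ccc1OCc1cn(CCOc2cc(=O)oc3ccccc23)nn1` differs from compound 3 in one place: phenyl in place of 3,4-dimethoxyphenyl on a double-bonded chain carbon bound to a double-bonded chain carbon.

Three measured steps change the group at this same place. One is a number 5 percentage points lower from compound 1 to compound 3 (within the scatter), and the others are a number 19 percentage points lower from compound 1 to compound 2 (beyond the scatter) and a number 14 percentage points higher from compound 2 to compound 3 (beyond the scatter). None of them tests phenyl itself, so they only suggest a likely size, from no visible change to a modest one. The thiophen-2-yl group of compound 2, which gives 66%, is closest in size to phenyl, so the expectation leans slightly downward. The expected result in this assay is a number 6 percentage points lower from compound 3 to compound 4 (within the scatter). For compound 4 the estimate is 74%, with an expected range of 60% to 87%.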

Compound 4, percent growth inhibition at one concentration: 54%
The estimate for compound 4 lay 20 percentage points above the measured number, and the stated range ends above it.
By their numbers in this assay, from the lowest: compound 4; then compound 2; then compounds 3 and 1 (each within the scatter of the next).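

In this assay, the plain phenyl group of compound 4 stands lowest of the four groups at this place on a double-bonded chain carbon: a number 26 percentage points lower from compound 3 to compound 4 (beyond the scatter), a number 12 percentage points lower from compound 2 to compound 4 (beyond the scatter), and a number 31 percentage points lower from compound 1 to compound 4 (beyond the scatter). The earlier compounds shown here hinted at only a moderate spread, but this position now proves more sensitive, and removing the two methoxy groups of 3,4-dimethoxyphenyl goes with a clear loss of growth inhibition rather than a change lost in the scatter. Nothing available here accounts for this drop.

Still open, as far as these compounds go, is whether both methoxy groups are needed or whether a phenyl ring carrying only one would hold the higher number. From the compounds shown here alone, it is also open how a phenyl ring carrying a dimethylamino group or a carboxylic acid would behave at this place.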